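The source may report more compounds than this note shows. Statements on the series, on what has been measured and on what is new or still open speak of the compounds shown alone.

Measured compounds:
compound 1, `O=C(CCC1=CCN(Cc2ccc(C(F)(F)F)cc2)C1=O)NO`: in a functional assay on NUGC-3 cells (Homo sapiens) for antiproliferative activity (a higher number here means a weaker inhibitor of growth, a lower number a stronger inhibitor of growth), compound 1 gives 3230 nM
compound 2, `COc1cccc(CN2CC=C(CCC(=O)NO)C2=O)c1`: in this assay compound 2 gives 1750 nM

Of these two numbers, compound 1 has the higher one, and compound 2 sits close below it; the gap lies within the scatter of repeat measurements, so no order between them can be claimed. Compound 3, `COc1ccc(CN2CC=C(CCC(=O)NO)C2=O)cc1`, is still to be measured in this assay. It differs from compound 1 in a single place: methoxy in place of trifluoromethyl on an aromatic carbon. Going by the values given here, no pair of measured compounds isolates this change, so there is no measured step to lean on. Compound 2 also carries a methoxy, and its number stands within the scatter of that of compound 1. The step expected in this assay is a 1.7-fold lower number from compound 1 to compound 3 (0.23 log units; within the scatter), leaning toward a lower number but not clearly beyond the scatter. Compound 3 is estimated at 1900 nM, with a range from 600 nM to 6000 nM.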

Compound 3, concentration for 50% growth inhibition: 1110 nM
Beside the measured number, compound 3's estimate is 1.7-fold (0.23 log units) above it; low and high end bracket the measured number.
By their numbers in this assay, from the lowest: compounds 3, 2 and 1 (each within the scatter of the next, the first and the last beyond it).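

In this assay, replacing trifluoromethyl with methoxy on an aromatic carbon, para to a large group, now has a measured size: a 2.9-fold lower number from compound 1 to compound 3 (0.46 log units; beyond the scatter). This is the first step among these compounds to stand beyond the scatter, so the group at this position does affect the number, although the step is modest and rests on a single pair. Nothing available bears on what lies behind the step.

On these data alone, whether this shift is specific to methoxy remains open, as a single pair cannot show how a hydroxyl, a fluorine or an amine at the same position would compare. As far as these compounds go, it is also open whether the step would hold on a related core with a longer chain.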